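The source may hold more compounds than are shown below. What is called first, only, known or untested is meant among the compounds shown, and "the series" means these compounds.

compound 1 `COc1cc2c(cc1CC=C(C)C)C(=O)C[C@@H](c1ccc(Oc3cccc([N+](=O)[O-])c3)cc1)O2`: 46%
compound 2 `CCCCOc1ccc([C@@H]2CC(=O)c3cc(CC=C(C)C)c(OC)cc3O2)cc1`: 60%
compound 3 `C#CCOc1ccc([C@@H]2CC(=O)c3cc(CC=C(C)C)c(OC)cc3O2)cc1`: 75%

In a functional assay on HCT-116 cells (Homo sapiens) for inhibition, read by sulforhodamine B assay, with a stated time of 48 h, tested at 50 uM (on this read-out lower numbers stand for less inhibition of growth and higher numbers for more inhibition of growth at the one concentration tested), compound 3 stands highest of the three at 75%. The steps leading to it are a number 15 percentage points higher from compound 2 to compound 3 (beyond the scatter) and a number 29 percentage points higher from compound 1 to compound 3 (beyond the scatter). The next compound, compound 4 `COc1cc2c(cc1CC=C(C)C)C(=O)C[C@@H](c1ccc(Oc3ccc(Br)cc3)cc1)O2`, differs from compound 3 in one place: 4-bromophenyl in place of propargyl on an oxygen on an aromatic ring. In words, this is 4-bromophenyl in place of propargyl on an oxygen on an aromatic ring. The closest guide is compound 1, which carries 3-nitrophenyl at that place and sits on the far side of the step of a number 29 percentage points higher from compound 1 to compound 3 (beyond the scatter). For the measured compounds named here, no compound with a bromine has been measured, so the guide is only partial. A drop of similar size is expected, read as a number 25 percentage points lower from compound 3 to compound 4 (beyond the scatter). Compound 4 is estimated at 50%, within a range of 35% to 65%.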

Compound 4, percent growth inhibition at one concentration: 76%
Compound 4: middle estimate off by 26 percentage points, on the low side; measured number above the stated range.
By their numbers in this assay, from the lowest: compound 1; then compound 2; then compounds 3 and 4 (each within the scatter of the next).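

In this assay a phenyl ring on this oxygen does not by itself lower the number: the result a number 1 percentage points higher from compound 3 to compound 4 (within the scatter) leaves 4-bromophenyl level with propargyl. What the ring carries can count, as a number 30 percentage points higher from compound 1 to compound 4 (beyond the scatter) comes with 4-bromophenyl in place of 3-nitrophenyl. A plain chain does not match the bromophenyl ring here, with a number 16 percentage points higher from compound 2 to compound 4 (beyond the scatter) for the swap from butyl.

No measured property of these groups accounts for these steps. Still open, on these data alone, is whether the bromine itself or its place on the ring matters, which 3-bromophenyl or 4-nitrophenyl would separate, and how an amine or a carboxylic acid on that ring would compare.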